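From a fluorophenyl thioether to a longer tolyl chain

This account rests on a few compounds, and the source may have more. Where it says the series, first, only, none or still open, it means among the compounds named here.

Compound 2 `C=C1CC[C@@H]2[C@](C)(CO)[C@H](O)CC[C@@]2(C)[C@@H]1C/C=C1/C(=O)OC[C@H]1OC(=O)CSc1ccc(F)cc1` and compound 1 `C=C1CC[C@@H]2[C@](C)(CO)[C@H](O)CC[C@@]2(C)[C@@H]1C/C=C1/C(=O)OCC1OC(=O)CSc1ccc(F)cc1` share the same atoms and bonds and differ only in the fact that one of compounds 1 and 2 is drawn with a defined configuration and the other without, at the place where they differ. In a functional assay on PC-3 cells (Homo sapiens) for inhibition, read by MTT assay, with a stated time of 48 h (a lower number here means a stronger inhibitor, a higher number a weaker inhibitor), compound 1 gives 13000 nM and compound 2 gives 14000 nM; the step of a 1.1-fold higher number from compound 1 to compound 2 (0.03 log units; within the scatter) lies within the scatter. Compound 2 thus holds the higher of the two numbers, with compound 1 close beside it.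

Compound 3 `C=C1CC[C@@H]2[C@](C)(CO)[C@H](O)CC[C@@]2(C)[C@@H]1C/C=C1/C(=O)OC[C@H]1OC(=O)CCCSc1ccc(C)cc1` differs from compound 2 by 2-((4-methylphenyl)sulfanyl)ethyl in place of (4-fluorophenyl)sulfanyl on a saturated chain carbon bound to a carbonyl carbon: in words, 2-((4-methylphenyl)sulfanyl)ethyl in place of (4-fluorophenyl)sulfanyl on a saturated chain carbon bound to a carbonyl carbon. Within the data shown here, the single measured step concerns a stereocentre and not this part of the molecule, so it offers no guidance on the size or direction of the change in this assay. No step beyond the scatter is therefore expected, though the uncertainty is wide. Compound 3 is estimated at 12000 nM, between 4000 nM and 40000 nM, which the expected step of a 1.2-fold lower number from compound 2 to compound 3 (0.07 log units; within the scatter) expresses.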

Compound 3, half-maximal inhibitory concentration: 16000 nM
Beside the measured number, compound 3's estimate is 1.3-fold (0.12 log units) below it, and the stated range covers the measured number.
By their numbers in this assay, from the lowest: compounds 1, 2 and 3 (each within the scatter of the next).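

In this assay, exchanging (4-fluorophenyl)sulfanyl for 2-((4-methylphenyl)sulfanyl)ethyl on a saturated chain carbon bound to a carbonyl carbon amounts to a 1.1-fold higher number from compound 2 to compound 3 (0.06 log units; within the scatter). This is the first change shown in this part of the molecule, and it shows that a longer chain ending in a 4-methylphenyl group leaves the number within the scatter. Nothing available bears on why the number stays there.

The chain length and the aryl group change together here, so the compounds shown cannot separate the two, and the effect of 4-methylphenyl on the original short chain remains unknown. On these data alone, it also remains open whether an amine or a carboxylic acid in place of the arylsulfanyl group would move the number beyond the scatter.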